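Cyano in place of methyl: the next step in the series

This account rests on a few compounds, and the source may have more. Where it says the series, first, only, none or still open, it means among the compounds named here.

compound 1 `O=C(O)COc1ccc(NCc2cccc(-c3ccccc3F)c2)cc1F` — 36.5 nM
compound 2 `Cc1ccccc1-c1cccc(CNc2ccc(OCC(=O)O)c(F)c2)c1` — 4.8 nM

In a functional assay on CHO cells for agonist activity at Free fatty acid receptor 1 (Homo sapiens), read by FLIPR and calcium flux (on this read-out higher numbers stand for an effect only at larger amounts of compound and lower numbers for an effect already at smaller amounts), compound 2 stands lowest of the two numbers; compound 1 is its nearest neighbour, and the step of a 7.6-fold lower number from compound 1 to compound 2 (0.88 log units; beyond the scatter) lies beyond the scatter. Compound 3 `N#Cc1ccccc1-c1cccc(CNc2ccc(OCC(=O)O)c(F)c2)c1` carries the change (cyano in place of methyl on an aromatic carbon). Among the compounds with values here, no measured step covers this exchange directly; the only step so far, a 7.6-fold lower number from compound 1 to compound 2 (0.88 log units; beyond the scatter), shows that the group at this place, ortho to a large group, moves the number by a modest amount. Compound 3 is therefore expected to shift within a comparable span, more likely toward a higher number, as a 3.1-fold higher number from compound 2 to compound 3 (0.49 log units; beyond the scatter). The estimate for compound 3 is 15 nM, with a range from 4 nM to 60 nM.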

Compound 3, half-maximal effective concentration: 729 nM
Compound 3: the middle estimate sits 49-fold (1.69 log units) below what was measured; the whole stated range lies below it.
By their numbers in this assay, from the lowest: compound 2; then compound 1; then compound 3.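

In this assay, within the data shown here, the exchange at this place, ortho to a large group, can cost far more than the earlier compounds showed: a 150-fold higher number from compound 2 to compound 3 (2.18 log units; beyond the scatter) is a much larger shift than a 7.6-fold lower number from compound 1 to compound 2 (0.88 log units; beyond the scatter) and runs the opposite way. Cyano also falls behind fluoro, with a 20-fold higher number from compound 1 to compound 3 (1.30 log units; beyond the scatter) as the step, so the three groups at this place do not differ by modest amounts only. Nothing at hand bears on the reason for this loss.

Still open, on these data alone, is where a chloro, methoxy or trifluoromethyl group would fall among methyl, fluoro and cyano. Also open, as far as these compounds go, is whether an aminomethyl or carboxamide group at this place would give a number as high as cyano does.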